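Extending the nitrile chain of compound 3

The source may hold more compounds than are shown below. What is called first, only, known or untested is meant among the compounds shown, and "the series" means these compounds.

In a physicochemical assay for solubility, measured as kinetic solubility, with a stated time of 1 h, at pH 7.4 (on this read-out higher numbers stand for higher solubility and lower numbers for lower solubility), compound 1 `Cn1ncc([N+](=O)[O-])c1C(=O)Nc1nc(-c2ccc(Cl)c(Cl)c2)cs1` reports < 1000 nM as a limit and not a number. Compound 2 `NC1=NN(c2ccc(Cl)c(Cl)c2)CC1` gives 69000 nM as a measured number. Compound 3 `N#CCC(=O)NC1=NN(c2ccc(Cl)c(Cl)c2)CC1` gives 202000 nM and so holds the higher of the two measured numbers. Going by the values given here, the only measured step shows a 2.9-fold higher number from compound 2 to compound 3 (0.47 log units; beyond the scatter) when (cyanomethyl)carbonyl takes the place of hydrogen on an amine nitrogen, a modest change beyond the scatter.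

Compound 4 `N#CCCC(=O)NC1=NN(c2ccc(Cl)c(Cl)c2)CC1` differs from compound 3 by cyanomethyl in place of cyano on a saturated chain carbon bound to a carbonyl carbon. The same difference reads as cyanomethyl to 2-cyanoethyl. Among the compounds with values here, no measured step covers this change directly. The step to compound 3 added the whole (cyanomethyl)carbonyl, while this change leaves the nitrile and carbonyl in place, so a smaller step than a 2.9-fold higher number from compound 2 to compound 3 (0.47 log units; beyond the scatter) is expected, with only a slight lean to a lower number. An estimated step of a 1.3-fold lower number from compound 3 to compound 4 (0.13 log units; within the scatter) is expected in this assay and would stay within the scatter. For compound 4 the expected value is an estimated 150000 nM with 70000 nM to 300000 nM as its range.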

Compound 4, solubility: 39000 nM
For compound 4 the middle estimate is 3.8-fold (0.59 log units) above the measured one; the whole stated range lies above it.
By their numbers in this assay, from the lowest: compounds 4 and 2 (each within the scatter of the next); then compound 3. At a limit, below all of these: compound 1.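

At the saturated chain carbon bound to a carbonyl carbon, cyanomethyl in place of cyano is not a silent change in this assay: it gives a 5.2-fold lower number from compound 3 to compound 4 (0.71 log units; beyond the scatter). Acylation of the amine nitrogen therefore does not by itself carry the higher number, since a 2.9-fold higher number from compound 2 to compound 3 (0.47 log units; beyond the scatter) is set against a 1.8-fold lower number from compound 2 to compound 4 (0.25 log units; within the scatter), and the latter does not separate the two compounds. Of the two acylated compounds, only compound 3 stands clear of compound 2, so the result here depends on cyanomethyl versus 2-cyanoethyl within the acyl group.

Nothing at hand bears on why the step from cyanomethyl to 2-cyanoethyl has this size. Still open, going by these compounds, is whether the nitrile is needed at all, which a methyl or hydroxymethyl group in its place would test, and whether a longer chain such as 3-cyanopropyl follows compound 4.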